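Chloro on the Oxindole Ring of Compound 3

A few compounds are considered here, and "the series" means these few. Any claim that something is new, unique, unknown or untested is made for them only; others in the source may bear on it.

Among the measured compounds shown here, the three compounds measured so far share an arylidene oxindole motif but differ in how the indole portion is substituted. In a functional assay on cells (Cancer cell lines, Homo sapiens) for cytotoxicity, with a stated time of 48 h (on this read-out lower numbers stand for stronger inhibition of growth and higher numbers for weaker inhibition of growth), compound 1 `COc1cc2c(/C=C3/C(=O)Nc4ccc(Cl)cc43)c(Cl)n(Cc3cc(OC)c(OC)c(OC)c3)c2cc1C` gives 7240 nM, compound 2 `O=C1/C(=C/c2c(Cl)[nH]c3ccccc23)c2ccccc2N1Cc1ccccc1` gives 77600 nM, and compound 3 `COc1c(/C=C2/C(=O)Nc3ccccc32)c2ccccc2n1-c1ccccc1` gives 4070 nM. Compound 3 carries the lowest of the three numbers; its gap to compound 1 lies within the scatter, so the two cannot be ranked, while compound 2 sits well beyond the scatter above both.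

Compound 4 `COc1c(/C=C2/C(=O)Nc3ccc(Cl)cc32)c2ccccc2n1-c1ccccc1` has not yet been measured in this assay. It differs from compound 3 in one place: chloro in place of hydrogen on an aromatic carbon. For the measured compounds named here, no measured pair isolates this change, so the step can only be anticipated. Compound 1 already bears a chloro on its oxindole ring, yet it differs from compound 3 in several other places, so it offers no direct guide. The step from compound 3 to compound 4 is expected to be small, a 1.3-fold lower number from compound 3 to compound 4 (0.10 log units; within the scatter), not clearly beyond the scatter in either direction. Compound 4 is accordingly estimated at 3200 nM, with a plausible range from 1200 nM to 9000 nM.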

Compound 4, concentration for total growth inhibition: 21900 nM
Compound 4: the middle estimate sits 6.8-fold (0.84 log units) below what was measured; measured number above the stated range.
By their numbers in this assay, from the lowest: compounds 3 and 1 (each within the scatter of the next); then compound 4; then compound 2.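

In this assay, among the compounds shown here, this is the first pair that isolates a single change, and it shows that this position is not indifferent to substitution: chloro in place of hydrogen on this aromatic carbon gives a 5.4-fold higher number from compound 3 to compound 4 (0.73 log units; beyond the scatter), a modest but real weakening of growth inhibition. The step is beyond the scatter even though the entering group is a single chlorine atom. Hydrogen is therefore preferred to chloro at this carbon, at least with the rest of compound 3 held fixed.

Nothing in the available data accounts for this loss. The compounds shown leave open whether a fluoro, a bromo, an amine or a carboxylic acid on this carbon would follow chloro or hydrogen, and whether chloro here would cost as much on a different core.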